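From Dimethylamino to Methylsulfanyl: Estimating Compound 4

This account rests on a few compounds, and the source may have more. Where it says the series, first, only, none or still open, it means among the compounds named here.

Three compounds sharing one core were tested in a functional assay on DU-145 cells (Homo sapiens) for inhibition, read by trypan blue exclusion, with a stated time of 96 h; on this read-out higher numbers stand for weaker inhibition of growth and lower numbers for stronger inhibition of growth. Compound 1 `O=C(O)c1ccc(C(=O)/C(=C\c2ccc(Br)cc2)SCc2ccc(Br)cc2)cc1` gives 1000 nM, compound 2 `O=C(O)c1ccc(C(=O)/C(=C\c2ccc(Cl)c([N+](=O)[O-])c2)SCc2ccc(Br)cc2)cc1` gives 500 nM, and compound 3 `CN(C)c1ccc(/C=C(/SCc2ccc(Br)cc2)C(=O)c2ccc(C(=O)O)cc2)cc1` gives 50000 nM, the highest of the three numbers. The step of a 50-fold higher number from compound 1 to compound 3 (1.70 log units; beyond the scatter) and the step of a 100-fold higher number from compound 2 to compound 3 (2.00 log units; beyond the scatter) show how far compound 3 sits behind the other two. Compound 4 `CSc1ccc(/C=C(/SCc2ccc(Br)cc2)C(=O)c2ccc(C(=O)O)cc2)cc1` differs from compound 3 by methylsulfanyl in place of dimethylamino on an aromatic carbon. Among the compounds with values here, no measured step covers methylsulfanyl, so the expectation rests on the two large steps toward compound 3, in which a group other than dimethylamino at that place went with far lower numbers. A partial return is therefore expected, a 10-fold lower number from compound 3 to compound 4 (1.00 log units; beyond the scatter), and compound 4 is estimated at 5000 nM in this assay, within a range from 1000 nM to 25000 nM.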

Compound 4, concentration for 50% growth inhibition: 10000 nM
Compound 4: the middle estimate sits 2.0-fold (0.30 log units) below what was measured, within the range that was stated.
By their numbers in this assay, from the lowest: compounds 2 and 1 (each within the scatter of the next); then compound 4; then compound 3.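

Methylsulfanyl recovers only part of the lost growth inhibition in this assay with a 5.0-fold lower number from compound 3 to compound 4 (0.70 log units; beyond the scatter) at this place on the aromatic ring. It still leaves a 10-fold higher number from compound 1 to compound 4 (1.00 log units; beyond the scatter) and a 20-fold higher number from compound 2 to compound 4 (1.30 log units; beyond the scatter) as gaps to the bromo and 4-chloro-3-nitrophenyl compounds. Compound 3 is therefore not alone in trailing these two, although dimethylamino remains the poorer of the two groups at this place.

Going by these compounds, whether a methoxy group or a primary amine here would sit nearer compound 3 or compound 1 stays open. No measurement shown gives a reason for these gaps.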